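The compounds below may be only part of what the source reports. "The series", "measured", "known", "first", "only" and "open" are said of these compounds alone.

Of the compounds shown here, three have been tested so far in an ADME assay on BHK-21 cells (Mesocricetus auratus) for cytotoxicity, read by MTT assay, with a stated time of 96 h (a lower number here means that less compound is tolerated, a higher number that more compound is tolerated), and none of them gave a number. Compound 1 `Cc1ccc(/N=N/c2ccc(NCCCN(C)C)cc2)cc1` reached only a limit, > 100000 nM. Compound 2 `Clc1cccc(/N=N/N2CCCCC2)c1` also reached only a limit, > 100000 nM. Compound 3 `O=[N+]([O-])c1ccc(/N=N/N2CCCC2)cc1` likewise gave only a limit, >= 100000 nM. Compound 3 therefore stands with the other two at the limit of the assay, and the three cannot be ranked against one another.

Compound 4 `c1ccc(/N=N/N2CCCC2)cc1` has not yet been measured. It has hydrogen in place of nitro on an aromatic carbon, and the change from compound 3 is hydrogen in place of nitro on an aromatic carbon. Within the data shown here, no measured pair of compounds shows what such a change does in this assay, so the data give no direct size for it. The expectation rests on compound 3, whose limit is >= 100000 nM, and it is for no step beyond the usual scatter in either direction. The estimated step, a number no higher from compound 3 to compound 4 (the limit leaves the size open), is expected to stay within that scatter. In this assay the estimate for compound 4 is 100000 nM, with an expected range from 50000 nM to 200000 nM, and the assay may well report only a limit again.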

Compound 4, half-maximal cytotoxic concentration: >= 100000 nM
Compound 4 gave a limit, no number; the forecaster's own chance of this, stated with the estimate: 75%; the middle value sits exactly at the limit.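

Among these compounds, compound 3 and compound 4 each gave only a limit in this assay, and no step between them can be read, so hydrogen in place of nitro on an aromatic carbon has no measurable size here. The four compounds shown leave open how they rank against one another and where any readable value in this assay would fall.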